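Pendant aryl swap on the shared core: compound 4

The source may hold more compounds than are shown below. What is called first, only, known or untested is meant among the compounds shown, and "the series" means these compounds.

The three measured compounds share one core and differ only in the substituent on the phenyl ring attached to it. In an assay for binding affinity to dual specificity mitogen-activated protein kinase kinase 4 (Homo sapiens), read by KINOMEscan, tested at 100 nM (on this read-out higher numbers stand for a weaker effect at the one concentration tested and lower numbers for a stronger effect), compound 1 `CCCS(=O)(=O)Nc1ccc(F)c(C(=O)c2n[nH]c3ncc(-c4ccccc4Cl)cc23)c1F` gives 9.3%, compound 2 `CCCS(=O)(=O)Nc1ccc(F)c(C(=O)c2n[nH]c3ncc(-c4ccccc4C)cc23)c1F` gives 7%, and compound 3 `CCCS(=O)(=O)Nc1ccc(F)c(C(=O)c2n[nH]c3ncc(-c4ccccc4OC)cc23)c1F` gives 1.9%. Compound 3 holds the lowest of the three numbers, yet a number 5.1 percentage points lower from compound 2 to compound 3 (within the scatter) and a number 7.4 percentage points lower from compound 1 to compound 3 (within the scatter), so the three are not separated on this assay; a number 2.3 percentage points lower from compound 1 to compound 2 (within the scatter) likewise.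

Compound 4 `CCCS(=O)(=O)Nc1ccc(F)c(C(=O)c2n[nH]c3ncc(-c4ccc(N(C)C)cc4)cc23)c1F` is not yet measured. It differs from compound 3 as follows: 4-(dimethylamino)phenyl in place of 2-methoxyphenyl on an aromatic carbon. All three measured steps concern the same phenyl ring and bear on this change only loosely: each swaps one substituent at the same place on that ring, and each stayed within the scatter. None moves the substituent to the 4-position or introduces a dimethylamino group, so the step to compound 4 is less well covered. With every prior step on this ring flat, no step beyond the scatter is expected in this assay for compound 4, whose number is expected near 4%, with a range of 0.5% to 15%; this means an expected step of a number 2.1 percentage points higher from compound 3 to compound 4 (within the scatter).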

Compound 4, a percentage reported as activity, at one concentration (the size of the read-out at that concentration, not a potency): 2.5%
Compound 4: middle estimate off by 1.5 percentage points, on the high side; low and high end bracket the measured number.
By their numbers in this assay, from the lowest: compounds 3, 4, 2 and 1 (each within the scatter of the next).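

For the compounds shown here, on this assay, 4-(dimethylamino)phenyl in place of 2-methoxyphenyl gives a number 0.6 percentage points higher from compound 3 to compound 4 (within the scatter) and the same group set against the other two pendant rings gives a number 4.5 percentage points lower from compound 2 to compound 4 (within the scatter) and a number 6.8 percentage points lower from compound 1 to compound 4 (within the scatter) so no pair among the four compounds is separated. The earlier steps shown here only exchanged one substituent at one place on the phenyl ring, whereas this change alters both the substituent and its place on that ring and still leaves the read-out within the scatter, which extends the flat picture at this position beyond the three earlier groups. Nothing shown here gives a reason for this flat result or tells how any of these groups acts on the read-out.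

Substituent and place change together in compound 4. The series cannot yet separate their contributions, and 4-methoxyphenyl or 2-(dimethylamino)phenyl would be the direct tests. Also open, from the compounds shown here alone, is whether this tolerance holds for a carboxylic acid or a primary amine on the same phenyl ring, or for a longer chain on that ring such as a butoxy group.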